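From Octyl to 3-Phenylprop-2-yn-1-yl

The source may hold more compounds than are shown below. What is called first, only, known or untested is meant among the compounds shown, and "the series" means these compounds.

Among the compounds with values here, in a functional assay on cells (T-cell line, Homo sapiens) for inhibition (a higher number here means a weaker inhibitor, a lower number a stronger inhibitor), compound 3 `CCCCCCCCN1CCC(COC(c2ccccc2)c2ccccc2)CC1` gives 700 nM, the lowest of the three numbers so far. Compound 1 `COc1cccc(CCCN2CCC(COC(c3ccccc3)c3ccccc3)CC2)c1` gives 1500 nM, and compound 2 `CCCCN1CCC(COC(c2ccccc2)c2ccccc2)CC1` gives 14000 nM.

Compound 4 `C(#Cc1ccccc1)CN1CCC(COC(c2ccccc2)c2ccccc2)CC1` has not yet been measured. Its difference from compound 3 is this: 2-phenylethynyl in place of heptyl on a saturated chain carbon bound to an amine nitrogen in a ring. Put simply, 2-phenylethynyl stands in place of heptyl on a saturated chain carbon bound to an amine nitrogen in a ring.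

Within the data shown here, three measured steps bear on this change. The large one, a 20-fold lower number from compound 2 to compound 3 (1.30 log units; beyond the scatter), shows how much the chain on the nitrogen can matter. Compound 1 is the nearest guide, as its chain also ends in an aromatic ring. The step of a 2.1-fold lower number from compound 1 to compound 3 (0.33 log units; beyond the scatter) is modest, while a 9.3-fold higher number from compound 1 to compound 2 (0.97 log units; beyond the scatter) is also modest but clearly larger. A chain ending in an aromatic ring therefore points to a modest rise from compound 3, not a fall. The expected change is a 3.6-fold higher number from compound 3 to compound 4 (0.55 log units; beyond the scatter). For compound 4, the estimated value is 2500 nM, with an expected range of 800 nM to 8000 nM.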

Compound 4, half-maximal inhibitory concentration: > 20000 nM
Compound 4 gave a limit, no number; the forecaster's own chance of this, stated with the estimate: 10%; middle value at least 8.0-fold (0.90 log units) away from the limit.
By their numbers in this assay, from the lowest: compound 3; then compound 1; then compound 2. At a limit, above all of these: compound 4.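

Compound 4 gives only a limit, not a number: the limit of > 20000 nM in this assay, at which 1 of the 4 values shown sits. Replacing octyl with 3-phenylprop-2-yn-1-yl gives an at least 28-fold higher number from compound 3 to compound 4 (1.45 log units; beyond the scatter), and replacing the saturated 2-(3-methoxyphenyl)ethyl with 2-phenylethynyl gives an at least 13-fold higher number from compound 1 to compound 4 (1.12 log units; beyond the scatter), so in these compounds an aromatic ring at the end of the chain does not by itself preserve inhibition. Against the shorter butyl chain the result is an at least 1.4-fold higher number from compound 2 to compound 4 (0.15 log units; that floor lies within the scatter), so no order can be claimed for that pair.

The compounds shown leave open whether the triple bond or the missing methoxy group matters more, as the chain of compound 4 differs from the chain of compound 1 in both. A plain 3-phenylpropyl chain and a 3-phenylprop-2-en-1-yl chain, with a double bond, would help separate the two.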